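Quinoline ureas: cytotoxicity in fibroblasts, methoxy for dimethylamino

The compounds below may be only part of what the source reports. "The series", "measured", "known", "first", "only" and "open" are said of these compounds alone.

Measured so far:
compound 1, `Cc1cc(NC(=O)Nc2cccc(C(N)=O)c2)c2ccccc2n1`: > 25000 nM
compound 2, `Cc1cc(NC(=O)Nc2ccc(N(C)C)cc2)c2ccccc2n1`: > 25000 nM
compound 3, `Cc1cc(NC(=O)Nc2ccc(Cl)cc2Cl)c2ccccc2n1`: 20000 nM

The read-out is an ADME assay on BJ cells (Homo sapiens) for cytotoxicity, with a stated time of 72 h; a lower number here means that less compound is needed, a higher number that more compound is needed for the effect. Compound 1 reports only a limit, > 25000 nM. Compound 2 also reports only a limit, > 25000 nM. Compound 2 therefore stands at the limit of > 25000 nM in this assay, at which 2 of the 3 values shown sit, where compound 1 stands as well, so there is no number for compound 2, only a floor on the concentration needed. Within the data shown here, compound 3 gives an actual number, 20000 nM, the single measured value in the set. Among the measured compounds shown here, no two measured compounds differ in one place, so no measured step exists to guide the next change.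

Compound 4, `COc1ccc(NC(=O)Nc2cc(C)nc3ccccc23)cc1`, is not yet measured. It differs from compound 2 by methoxy in place of dimethylamino on an aromatic carbon. Because compound 2 sits at the limit of > 25000 nM in this assay, at which 2 of the 3 values shown sit, there is no room to show a gain, and nothing in the set suggests the exchange moves the value beyond the scatter. The expected step that the limit leaves unreadable from compound 2 to compound 4 is none beyond the scatter. For compound 4 the estimated value in this assay is 30000 nM, in the range 15000 nM to 60000 nM, most likely again as a limit.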

Compound 4, half-maximal effective concentration: > 25000 nM
Compound 4: only a limit was reported; the forecaster's own chance of this, stated with the estimate: 70%; the middle value is on the limit's open side.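

Compound 2 and compound 4 both report only a limit, so methoxy in place of dimethylamino gives no readable step: the limit of > 25000 nM in this assay, at which 3 of the 4 values shown sit.

The compounds shown leave open how far either compound lies from that limit, and whether methoxy and dimethylamino differ at all.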